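The compounds below may be only part of what the source reports. "The series", "measured", "known", "first", "only" and "open" are said of these compounds alone.

Compound 1 `Clc1cccc(/N=N/N2CCCCC2)c1` is tested in an ADME assay on BHK-21 cells (Mesocricetus auratus) for cytotoxicity, read by MTT assay, with a stated time of 96 h; a lower number here means that less compound is tolerated, a higher number that more compound is tolerated. In this assay compound 1 gives > 100000 nM, which is a limit of the assay rather than a number. Compound 2 `Brc1cccc(/N=N/N2CCCCC2)c1` differs from it by bromo in place of chloro on an aromatic carbon. In this assay compound 2 gives > 100000 nM, again a limit. The step that the two limits leave unreadable from compound 1 to compound 2 therefore cannot be sized; what is known is the limit of > 100000 nM in this assay, at which 3 of the 3 values shown sit. Compound 3 `Clc1ccc(/N=N/N2CCCC2)cc1` has a core whose difference from that of compound 1 is not broken down here. In this assay compound 3 gives > 100000 nM, also a limit. Compound 4 `Brc1ccc(/N=N/N2CCCC2)cc1` differs from compound 3 by bromo in place of chloro on an aromatic carbon; this is the same kind of change as from compound 1 to compound 2, though there it sits meta to a group of 8 heavy atoms and here para to a group of 7 heavy atoms. The step that the limit leaves unreadable from compound 3 to compound 4 is expected to be small, resting on compound 1 reaching > 100000 nM and compound 2 reaching > 100000 nM. Compound 4 is estimated at 150000 nM in this assay.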

Compound 4, half-maximal cytotoxic concentration: > 100000 nM
Compound 4: no number, only a limit; the forecaster's own chance of this, stated with the estimate: 85%; the middle value does not contradict the limit.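

For the compounds shown here, compound 3 and compound 4 both give only a limit, so no step between them can be read: the limit of > 100000 nM in this assay, at which 4 of the 4 values shown sit.
The compounds shown leave open at what concentration any of them becomes toxic to the cells, and whether bromo and chloro differ in this.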